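The source may report more compounds than this note shows. Statements on the series, on what has been measured and on what is new or still open speak of the compounds shown alone.

In a functional assay on MCF7 cells (Homo sapiens) for inhibition, read by CCK-8 assay, with a stated time of 48 h (on this read-out higher numbers stand for weaker inhibition and lower numbers for stronger inhibition), two compounds have values so far:
- compound 1 `COc1cc(-c2ccnc3cc(-c4ccc(Cl)cc4)nn23)cc(OC)c1OC` gives 2320 nM 
- compound 2 `COc1cc(-c2ccnc3cc(-c4ccc(C(F)(F)F)cc4)nn23)cc(OC)c1OC` gives 2440 nM 

Among the compounds with values here, compound 2 has one measured neighbour, and the sole step between them (a 1.1-fold higher number from compound 1 to compound 2 (0.02 log units; within the scatter)) leaves it level on the numbers. Compound 3 `COc1cc(-c2ccnc3cc(-c4ccc5cnn(C)c5c4)nn23)cc(OC)c1OC` departs from compound 2 by a larger exchange (1-methyl-1H-indazol-6-yl in place of 4-(trifluoromethyl)phenyl on an aromatic carbon) in which 1-methyl-1H-indazol-6-yl takes the place of 4-(trifluoromethyl)phenyl on an aromatic carbon. The measured step swapped only chloro for trifluoromethyl and kept the phenyl ring, so it says little about replacing the whole group. Within the data shown here, no measured compound carries 1-methyl-1H-indazol-6-yl. Among the measured compounds shown here, a step beyond the scatter is nevertheless expected in this assay toward a lower number, though no measured step supports that direction. The estimated step is a 20-fold lower number from compound 2 to compound 3 (1.31 log units; beyond the scatter) and remains uncertain. For compound 3 the expected value is 120 nM with an estimated range from 15 nM to 1500 nM as the upper end.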

Compound 3, half-maximal inhibitory concentration: 279 nM
Compound 3: the middle estimate sits 2.3-fold (0.37 log units) below what was measured, within the range that was stated.
By their numbers in this assay, from the lowest: compound 3; then compounds 1 and 2 (each within the scatter of the next).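

In this assay this position proved able to shift the number. Exchanging chloro for trifluoromethyl on the phenyl ring had stayed within the scatter, whereas replacing the whole group with 1-methyl-1H-indazol-6-yl gave an 8.7-fold lower number from compound 2 to compound 3 (0.94 log units; beyond the scatter), and likewise an 8.3-fold lower number from compound 1 to compound 3 (0.92 log units; beyond the scatter). The two steps are close in size, so the gain appears whichever of the two phenyl groups leaves, and it comes with a fused five-membered aromatic ring carrying nitrogen. Nothing measured here accounts for the gain.

The compounds shown do not separate the contributions of the ring nitrogens, the methyl group and the fused ring. An indazole without the methyl, an indole, a pyridine or a phenyl ring bearing an amine would each test a different part of that change.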